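Putting an amino group on compound 2

The source may hold more compounds than are shown below. What is called first, only, known or untested is meant among the compounds shown, and "the series" means these compounds.

Going by the values given here, in a functional assay on HL-60 cells (Homo sapiens) for antiproliferative activity (a lower number here means a stronger inhibitor, a higher number a weaker inhibitor), compound 2 (`COc1ccc(-c2snnc2-c2cc(OC)c(OC)c(OC)c2)cc1`) gives 14.5 nM as the lower of the two numbers so far, while compound 1 (`COc1ccc(-c2snnc2-c2cc(OC)c(OC)c(OC)c2)cc1OC`) gives 60.9 nM with one more methoxy group. Compound 3 (`COc1ccc(-c2snnc2-c2cc(OC)c(OC)c(OC)c2)cc1N`) has amino in place of hydrogen on an aromatic carbon, ortho to a methoxy group, and amino in place of hydrogen on an aromatic carbon counts this change. Among the compounds with values here, one measured step bears on it: hydrogen in place of methoxy gave a 4.2-fold lower number from compound 1 to compound 2 (0.62 log units; beyond the scatter) as a modest gain. That step suggests that a group at this carbon may raise the number, but amino is not methoxy, so only a smaller rise is expected. The estimated change is a 1.4-fold higher number from compound 2 to compound 3 (0.14 log units; within the scatter) and is not expected to clear the scatter. For compound 3 the estimated value is 20 nM with an expected range from 6 nM to 70 nM in this measurement.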

Compound 3, half-maximal inhibitory concentration: 1.8 nM
Estimate against measurement, compound 3: 11-fold (1.05 log units) above; the measured number lies below the stated range.
By their numbers in this assay, from the lowest: compound 3; then compound 2; then compound 1.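

In this assay, this carbon, ortho to a methoxy group, proves not to be a place where any added group raises the number: amino in place of hydrogen gave an 8.1-fold lower number from compound 2 to compound 3 (0.91 log units; beyond the scatter). Compared directly with methoxy at the same carbon, amino gave a 34-fold lower number from compound 1 to compound 3 (1.53 log units; beyond the scatter), so the identity of the group here matters a great deal, with methoxy and amino moving the number in opposite directions from hydrogen. Nothing measured here explains why these two groups differ.

Still open, from the compounds shown here alone, is how much of the gain depends on the hydrogens of the amino group, which a methylamino, dimethylamino or acetamido group at this carbon would test. A hydroxyl group would show whether a group other than amino can give a similar gain.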